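Swapping a Benzyl for an Ester on a Triazole Arm

This account rests on a few compounds, and the source may have more. Where it says the series, first, only, none or still open, it means among the compounds named here.

compound 1, `O=C1C[C@H](OCc2cn(-c3cccc4ccccc34)nn2)[C@H]2CO[C@@H]1O2`, in a functional assay on MDA-MB-231 cells (Homo sapiens) for cytotoxicity, read by MTT assay, with a stated time of 48 h (on this read-out lower numbers stand for stronger inhibition and higher numbers for weaker inhibition), gives 21900 nM
compound 2, `CC(=O)N(Cc1cn(Cc2ccccc2)nn1)[C@H]1CC(=O)[C@@H]2OC[C@H]1O2`, in this assay gives > 50000 nM

The value for compound 2 is a limit of the assay, not a number: compound 2 sits at the limit of > 50000 nM in this assay, at which 1 of the 2 values shown sits. Compound 3, `COC(=O)Cn1cc(CN(C(C)=O)[C@H]2CC(=O)[C@@H]3OC[C@H]2O3)nn1`, differs from compound 2 by methoxycarbonyl in place of phenyl on a saturated chain carbon bound to an aromatic nitrogen; cut one bond further out, the difference reads benzyl to (methoxycarbonyl)methyl. Among the compounds with values here, no measured pair shows such a change, so its size in this assay is unknown. Compound 3 is expected to stay weak, with an estimated 60000 nM, ranging from 20000 nM to 150000 nM. The expected step is a step that the limit leaves unreadable from compound 2 to compound 3.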

Compound 3, half-maximal inhibitory concentration: > 50000 nM
Compound 3: no number, only a limit; the forecaster's own chance of this, stated with the estimate: 75%; the middle value does not contradict the limit.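

Compound 2 and compound 3 each give only a limit of the assay, not a number, so no step can be read between them: the limit of > 50000 nM in this assay, at which 2 of the 3 values shown sit.

Going by these compounds, whether methoxycarbonyl in place of phenyl changes the cytotoxicity in this assay at all stays open.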